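Replacing the Carboxy Group of Compound 1 with an Amide-Linked Acid

The source may report more compounds than this note shows. Statements on the series, on what has been measured and on what is new or still open speak of the compounds shown alone.

Measured compounds:
- compound 1, `CCCCCCCCCCCCCCC(NC(=O)OC(C)(C)C)C(=O)O`: 5.1%
- compound 2, `CCCCCCCCCCCCCCC(CO)N(CC)CC`: 12.8%
- compound 3, `CCCCCCCCCCCCCCC(CO)NCCCCCC`: 14.6%

All three were tested in an ADME assay on cells (Splenocyte, Mus musculus, strain BALB/c) for cytotoxicity, read by MTT assay, tested at 10 ug/mL; on this read-out lower numbers stand for a weaker effect and higher numbers for a stronger effect at the one concentration tested. Compound 1 stands at the low end of the three numbers; compound 2 gives 12.8% and compound 3 gives 14.6%, and neither is separated from compound 1 beyond the scatter. Among the measured compounds shown here, the only measured step, a number 1.8 percentage points higher from compound 2 to compound 3 (within the scatter), concerns the nitrogen substituent of the amino alcohols and stays within the scatter.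

Compound 4, `CCCCCCCCCCCCCCC(CNC(=O)CCCC(=O)O)NC(=O)OC(C)(C)C`, has not yet been measured in this assay. It differs from compound 1 as follows: (((3-carboxypropyl)carbonyl)amino)methyl in place of carboxy on a saturated chain carbon bound to an amide-type nitrogen and a saturated chain carbon. For the measured compounds named here, no measured step touches the carboxy position, so nothing among the three compounds speaks directly to this change; what the data do show is that every number so far, across quite different substituents, lies in a narrow low band. On that basis the step of a number 3.9 percentage points higher from compound 1 to compound 4 (within the scatter) is expected to remain within the scatter, with no direction beyond it. Compound 4 is therefore estimated to give about 9%, in the range 2% to 22%.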

Compound 4, a percentage reported as activity, at one concentration (the size of the read-out at that concentration, not a potency): 1.2%
Beside the measured number, compound 4's estimate is 7.8 percentage points above it; the whole stated range lies above it.
By their numbers in this assay, from the lowest: compounds 4, 1, 2 and 3 (each within the scatter of the next, the first and the last beyond it).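

In this assay, the carboxy position of compound 1 now has a measured step of its own: placing (((3-carboxypropyl)carbonyl)amino)methyl in place of carboxy, on a saturated chain carbon bound to an amide-type nitrogen and a saturated chain carbon, gives a number 3.9 percentage points lower from compound 1 to compound 4 (within the scatter). The change is large in structure, with 10 heavy atoms entering and 3 leaving, and an amide-type nitrogen added, yet the read-out does not move beyond the scatter, so this size of change at this position has no measurable consequence here. No evidence on the reason for this result is at hand.

The compounds shown leave open whether the read-out would hold if the new group ended in a primary amine or a methyl ester in place of its carboxy. They also leave open whether a longer chain than the 3-carboxypropyl part of the group, or a change elsewhere on the core of compound 1, would give a step beyond the scatter.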